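Isoquinolinyl in Place of Dichlorophenyl on a Hydroxamic Acid

A few compounds are considered here, and "the series" means these few. Any claim that something is new, unique, unknown or untested is made for them only; others in the source may bear on it.

Measured so far, in an assay on Sf9 cells for inhibition of protein deacetylase HDAC6 (Homo sapiens), read by fluorescence, with a stated time of 40 min, tested at 100 nM; on this read-out lower numbers stand for less inhibition and higher numbers for more inhibition at the one concentration tested (going by the name of the read-out):
- compound 1 `CNC(=O)c1ccc(NCc2nc(-c3ccccc3)nn2-c2ccccc2)cc1` gives -3.6%
- compound 2 `O=C(NO)c1ccc(NCc2nc(-c3ccc(Cl)c(Cl)c3)nn2-c2ccccc2)cc1` gives 34.5%
- compound 3 `NC(=O)c1ccc(NCc2nc(-c3ccccc3)nn2-c2ccccc2)cc1` gives -4.4%

Compound 2 stands highest of the three numbers in this assay; compound 1 and compound 3 lie far below it, beyond the scatter. For the measured compounds named here, the one step with a single change, a number 0.8 percentage points lower from compound 1 to compound 3 (within the scatter), concerns the amide nitrogen and is within the scatter.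

Compound 4 `O=C(NO)c1ccc(NCc2nc(-c3cccc4cnccc34)nn2-c2ccccc2)cc1` is made from compound 2 by one change: isoquinolin-5-yl in place of 3,4-dichlorophenyl on an aromatic carbon. Going by the values given here, no measured step touches this position of the shared core, and compound 2 differs from compound 1 and compound 3 in more than one place, so nothing recorded shows how the number should move. The expectation therefore rests on compound 2 alone, with a wide range in this assay.

The estimate for compound 4 is 32%, between 8% and 58%, which is expected to mean a step of a number 2.5 percentage points lower from compound 2 to compound 4 (within the scatter), no direction claimed.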

Compound 4, a percentage reported as inhibition, at one concentration (the size of the read-out at that concentration, not a potency): 40.2%
For compound 4 the middle estimate is 8.2 percentage points below the measured one; the range from low to high includes it.
By their numbers in this assay, from the lowest: compounds 3 and 1 (each within the scatter of the next); then compounds 2 and 4 (each within the scatter of the next).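

In this assay, putting isoquinolin-5-yl in place of 3,4-dichlorophenyl gives a number 5.7 percentage points higher from compound 2 to compound 4 (within the scatter), so the two compounds cannot be told apart on this read-out. This position on the five-membered aromatic ring can therefore carry either group, one with two chlorine atoms on a single carbon ring and the other with a second six-membered aromatic ring holding a ring nitrogen, without a measurable change in the number. No supporting measurement explains why the two groups read alike.

Going by these compounds, both compounds were read at a single concentration, so any difference in potency between them remains unknown. On these data alone, it also remains open whether this position needs a large aromatic group at all, since a smaller group such as a methyl, an amine or a carboxylic acid does not appear here.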